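This account rests on a few compounds, and the source may have more. Where it says the series, first, only, none or still open, it means among the compounds named here.

In a functional assay on HT-29 cells (Homo sapiens) for cytotoxicity, read by MTT assay, with a stated time of 24 h, tested at 6.4 ug/mL (on this read-out higher numbers stand for a stronger effect at the one concentration tested and lower numbers for a weaker effect), compound 3, with the structure `Cn1nnnc1SCC(=O)Nc1ccc(-c2nc(-c3ccccc3)c(-c3ccccc3)n2C)cc1`, gives 60.6%, the highest of the three values on record. Compound 2, `Cn1c(-c2ccc(NC(=O)CSc3nc4ccccc4s3)cc2)nc(-c2ccccc2)c1-c1ccccc1`, gives 36.8%, and compound 1, `Cc1ccc2oc(SCC(=O)Nc3ccc(-c4nc(-c5ccccc5)c(-c5ccccc5)n4C)cc3)nc2c1`, gives 25.6%. The measured steps all exchange the group on the sulfur: a number 11.2 percentage points higher from compound 1 to compound 2 (beyond the scatter), a number 35 percentage points higher from compound 1 to compound 3 (beyond the scatter) and a number 23.8 percentage points higher from compound 2 to compound 3 (beyond the scatter).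

Compound 4, `CCN1CCN(CC(=O)Nc2ccc(-c3nc(-c4ccccc4)c(-c4ccccc4)n3C)cc2)CC1`, is unmeasured. Its difference from compound 3 is 4-ethylpiperazin-1-yl in place of (1-methyl-1H-tetrazol-5-yl)sulfanyl on a saturated chain carbon bound to a carbonyl carbon. Within the data shown here, none of the measured steps bears directly on this change, since each of them keeps the sulfur in place and only varies the ring attached to it, whereas here the whole sulfanyl group gives way to a saturated ring joined through nitrogen. The measured steps show only that this position is sensitive, with moves of modest to large size. Given that, a step of a number 18.6 percentage points lower from compound 3 to compound 4 (beyond the scatter) is expected, downward but uncertain in size, and compound 4 is estimated to give 42%, within a range from 18% to 66%.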

Compound 4, a percentage reported as activity, at one concentration (the size of the read-out at that concentration, not a potency): 17.2%
The estimate for compound 4 lay 24.8 percentage points above the measured number, outside the stated range (below it).
By their numbers in this assay, from the lowest: compounds 4 and 1 (each within the scatter of the next); then compound 2; then compound 3.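

In this assay, among these compounds, the earlier compounds varied only the ring on the sulfur, whereas this change removes the whole sulfanyl group from the saturated chain carbon bound to a carbonyl carbon and gives a number 43.4 percentage points lower from compound 3 to compound 4 (beyond the scatter), a number 19.6 percentage points lower from compound 2 to compound 4 (beyond the scatter) and a number 8.4 percentage points lower from compound 1 to compound 4 (within the scatter). The effect of bringing in 4-ethylpiperazin-1-yl therefore depends on the group it is compared with: compound 4 falls well short of the two sulfanyl compounds with the higher values, but cannot be told apart from compound 1. No available evidence accounts for these differences.

The compounds shown leave open whether the large step from compound 3 follows from losing the sulfur, losing the 1-methyl-1H-tetrazol-5-yl ring, or gaining the 4-ethylpiperazin-1-yl ring. From the compounds shown here alone, a morpholin-4-yl ring or an unsubstituted piperazin-1-yl ring at this place would extend the comparison, and the role of the ethyl group also remains open.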